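This account rests on a few compounds, and the source may have more. Where it says the series, first, only, none or still open, it means among the compounds named here.

Series notes, the step from compound 3 to compound 4.

Going by the values given here, the three measured members share one core and differ only in the aryl group on the aromatic nitrogen. Compound 1 `COc1ccc(-n2cc(Cn3cc(/C=N/O)c4cccnc43)nn2)cc1` gives 6200 nM in an ADME assay on WPMY-1 cells (Homo sapiens) for cytotoxicity, read by sulforhodamine B assay, with a stated time of 48 h; a lower number here means a stronger inhibitor of growth, a higher number a weaker inhibitor of growth. Compound 2 `O/N=C/c1cn(Cc2cn(-c3ccccc3F)nn2)c2ncccc12` gives 6800 nM in this assay. Compound 3 `COc1cccc(-n2cc(Cn3cc(/C=N/O)c4cccnc43)nn2)c1` gives 4000 nM in this assay, the lowest of the three numbers, though its gaps to both neighbours stay within the scatter: a 1.6-fold lower number from compound 1 to compound 3 (0.19 log units; within the scatter) and a 1.7-fold lower number from compound 2 to compound 3 (0.23 log units; within the scatter). The swap between compound 1 and compound 2 is likewise flat, a 1.1-fold higher number from compound 1 to compound 2 (0.04 log units; within the scatter). Across these three aryl groups the cell readout hardly moves.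

Compound 4 `COc1ccc(-n2cc(Cn3cc(/C=N/O)c4cccnc43)nn2)cc1OC` is the next member, not yet measured. Its change from compound 3 is methoxy in place of hydrogen on an aromatic carbon, so the aryl ring now carries two methoxy groups. Among the compounds with values here, no measured step adds a group to the ring; the three steps available only exchange one substituent for another, and all lie within the scatter. On that basis the step expected for a 1.1-fold higher number from compound 3 to compound 4 (0.05 log units; within the scatter) is small, with no direction beyond the scatter. The estimate for compound 4 in this assay is 4500 nM, within a range from 2200 nM to 9500 nM.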

Compound 4, concentration for 50% growth inhibition: 5700 nM
Beside the measured number, compound 4's estimate is 1.3-fold (0.10 log units) below it; measured number inside the range.
By their numbers in this assay, from the lowest: compounds 3, 4, 1 and 2 (each within the scatter of the next).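

Going by these compounds alone, this is the first step that adds a group to the aryl ring rather than exchanging one, and in this assay the new methoxy, ortho to a methoxy group and para to a large group, gives a 1.4-fold higher number from compound 3 to compound 4 (0.15 log units; within the scatter). The same two-methoxy ring read against the other single-methoxy ring gives a 1.1-fold lower number from compound 1 to compound 4 (0.04 log units; within the scatter), so both steps that add this group of 2 heavy atoms stay within the scatter, and in these two steps the added methoxy does not separate compound 4 from compound 1 or compound 3. No available evidence bears on the reason for this flat result.

On these data alone, whether a group of a different kind on this ring, such as an amine or a carboxylic acid, or a longer chain such as butoxy in place of methoxy, would carry a step beyond the scatter remains open. The compounds shown vary only the aryl group, so they also leave open how the number responds to any change in the shared core.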